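This account rests on a few compounds, and the source may have more. Where it says the series, first, only, none or still open, it means among the compounds named here.

Among the measured compounds shown here, in an assay on isolated protein for inhibition of Indoleamine 2,3-dioxygenase 1 (Homo sapiens), with a stated time of 60 min, tested at 10 uM (a lower number here means less inhibition, a higher number more inhibition at the concentration tested (going by the name of the read-out)), compound 1 `Clc1ccc2[nH]c(SCc3ccccc3Oc3ccccc3)nc2c1` gives 30%, the higher of the two numbers measured so far; compound 2 `O=S(=O)(Cc1ccccc1)c1ccccc1CSc1nc2cc(Cl)ccc2[nH]1` gives 24% in this assay, and the two numbers lie within the usual scatter, so neither can be called stronger. Compound 3 `Clc1ccc2[nH]c(SCc3ccccc3CCc3ccccc3)nc2c1` differs from compound 1 in one place: phenethyl in place of phenoxy on an aromatic carbon. For the measured compounds named here, no step between two measured compounds is available to guide the expectation, so only a small change is expected, if any beyond the scatter, the estimated step being a number 2 percentage points lower from compound 1 to compound 3 (within the scatter). For compound 3 the expected value in this assay is 28%, ranging from 10% to 46%.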

Compound 3, a percentage reported as inhibition, at one concentration (the size of the read-out at that concentration, not a potency): 47%
The estimate for compound 3 lay 19 percentage points below the measured number, outside the stated range (above it).
By their numbers in this assay, from the lowest: compounds 2 and 1 (each within the scatter of the next); then compound 3.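

In this assay, phenethyl in place of phenoxy on this aromatic carbon gives a number 17 percentage points higher from compound 1 to compound 3 (beyond the scatter), the first change shown to lie beyond the scatter, so the group at this position can alter inhibition. Phenoxy carries a hydrogen-bond acceptor and phenethyl has none, while phenethyl is also the larger group, so this one step cannot separate those two differences. Nothing measured here explains the rise. Open questions remain: whether a longer chain such as phenylpropyl would raise the number further, and how an amine on the outer ring would change it.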